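Adding trifluoromethyl to a small pyrazolopyridine amidine

The source may report more compounds than this note shows. Statements on the series, on what has been measured and on what is new or still open speak of the compounds shown alone.

Measured compounds:
- compound 1, `Cn1nc(-c2ccccc2)c2cc(C(=N)Nc3cccc(C(F)(F)F)c3)ncc21`: 20900 nM
- compound 2, `N=C(Nc1cccc(C(F)(F)F)c1)c1cc2cn[nH]c2cn1`: > 50000 nM
- compound 3, `Cn1ncc2cc(C(=N)Nc3ccccc3)ncc21`: "not determined" (no result reported)

All three compounds share a bicyclic core bearing an amidine that links to an aromatic ring. They were tested in a functional assay on PC-3 cells (Homo sapiens) for cytotoxicity, read by MTT assay, with a stated time of 72 h; on this read-out lower numbers stand for stronger inhibition and higher numbers for weaker inhibition. Compound 1 gives 20900 nM, a weak effect. Compound 2 reaches only a limit of the assay, > 50000 nM, so no number exists for it. For compound 3 the result in this assay is "not determined" (no result reported), so there is no number to place it among the others; of the values shown, one sits at the limit of > 50000 nM in this assay, at which 1 of the 3 values shown sits, and only compound 1 carries a measured figure.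

Compound 4, `Cn1ncc2cc(C(=N)Nc3cccc(C(F)(F)F)c3)ncc21`, differs from compound 3 by trifluoromethyl in place of hydrogen on an aromatic carbon. The change puts trifluoromethyl on an aromatic carbon of a six-membered aromatic ring of carbon only, meta to a large group, the same ring pattern seen in compound 1 and compound 2. Within the data shown here, with no measured step between compounds differing in one place, the size and direction of this change cannot be read from the data, and any step is expected to stay within the scatter of this assay.

Compound 4 is estimated at 30000 nM, expected within 8000 nM to 100000 nM, weak like compound 1 at 20900 nM.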

Compound 4, half-maximal inhibitory concentration: 50000 nM
The estimate for compound 4 lay 1.7-fold (0.22 log units) below the measured number, and the stated range covers the measured number.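

In this assay, among these compounds, compound 4 gives the first number for the small core with trifluoromethyl on the six-membered aromatic ring and no phenyl on the core. Among the compounds shown here, the one readable step is a 2.4-fold higher number from compound 1 to compound 4 (0.38 log units; beyond the scatter), which comes with hydrogen in place of phenyl on an aromatic carbon; this modest rise lies beyond the usual scatter, so in this pair the compound with phenyl is the more potent. Compound 2 carries only a limit. With methyl in place of hydrogen on an aromatic nitrogen, the step is a number no higher from compound 2 to compound 4 (the limit leaves the size open) and its size cannot be read: the limit of > 50000 nM in this assay, at which 1 of the 4 values shown sits.

Compound 3 has no number, so the effect of trifluoromethyl in place of hydrogen at the position meta to a large group remains unsized, and so does any comparison with an amine or a carboxylic acid at that aromatic carbon. From the compounds shown here alone, with only phenyl and hydrogen to compare on the core's aromatic carbon, it also remains open what a longer chain there would give.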